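The source may hold more compounds than are shown below. What is called first, only, known or untested is meant among the compounds shown, and "the series" means these compounds.

In a functional assay on NCI-H1650 cells (Homo sapiens) for cytotoxicity, read by MTT assay, with a stated time of 72 h (on this read-out lower numbers stand for stronger inhibition and higher numbers for weaker inhibition), compound 3 `CCCN1C/C(=C\c2ccc(OC)c(OC)c2)C(=O)/C(=C/c2ccc(OC)c(OC)c2)C1` gives 16000 nM and sits within the scatter of compound 1 `COc1ccc(/C=C2\CNC/C(=C\c3ccc(OC)c(OC)c3)C2=O)cc1OC`, which gives 16700 nM in the same test. Compound 2 `COc1cc(/C=C2\CN(C)C/C(=C\c3cc(OC)c(OC)c(OC)c3)C2=O)cc(OC)c1OC` gives 1500 nM as a clearly lower number than both, but it differs from them in more than one place and offers no guide here.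

The change to compound 4 `CCN1C/C(=C\c2ccc(OC)c(OC)c2)C(=O)/C(=C/c2ccc(OC)c(OC)c2)C1` is small: propyl becomes ethyl, with hydrogen in place of methyl on a saturated chain carbon, two bonds along the chain from an amine nitrogen in a ring.

Within the data shown here, one measured step bears on this: a 1.0-fold lower number from compound 1 to compound 3 (0.02 log units; within the scatter) shows that swapping hydrogen for propyl on that nitrogen left the number within the scatter. Ethyl is a shorter chain than the propyl of compound 3, so no shift beyond the scatter is expected in either direction, and the expected change is no change at the digits printed from compound 3 to compound 4 (within the scatter) in this assay on this reasoning. For compound 4 the estimated value is 16000 nM with an expected range from 8000 nM to 32000 nM in this test.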

Compound 4, half-maximal inhibitory concentration: 12000 nM
For compound 4 the middle estimate is 1.3-fold (0.12 log units) above the measured one, within the range that was stated.
By their numbers in this assay, from the lowest: compound 2; then compounds 4, 3 and 1 (each within the scatter of the next).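

In this assay, shortening propyl to ethyl gives a 1.3-fold lower number from compound 3 to compound 4 (0.12 log units; within the scatter) and so adds a second chain length to the picture at this place. Ethyl in place of hydrogen on the amine nitrogen in the ring gives a 1.4-fold lower number from compound 1 to compound 4 (0.14 log units; within the scatter) as well, so hydrogen, ethyl and propyl there cannot be told apart across compound 1, compound 3 and compound 4, at least in this one test. Nothing here offers an explanation for this flat result.

On these data alone, whether a longer chain, a benzyl group or a chain ending in a carboxylic acid on that nitrogen would shift the number remains open. Compound 2 gives 1500 nM but differs from these compounds in more than one place, so which of its differences matters also stays unresolved.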